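Ring substituent swap on the amide-bound phenyl

The source may report more compounds than this note shows. Statements on the series, on what has been measured and on what is new or still open speak of the compounds shown alone.

Compound 3 `COc1ccc(NC(=O)c2c(NO)cc(-c3ccccc3)oc2=O)cc1` is one of three close relatives tested in an ADME assay on Huh-7 cells (Homo sapiens) for cytotoxicity, read by a luciferase reporter and WST assay, with a stated time of 3 days; on this read-out lower numbers stand for higher toxicity in this test and higher numbers for lower toxicity in this test. In this assay compound 3 gives > 20000 nM, which is a limit of the assay rather than a number. Compound 1 `O=C(Nc1ccc(Cl)cc1)c1c(NO)cc(-c2ccccc2)oc1=O` gives > 20000 nM, also a limit. Compound 2 `O=C(Nc1ccc(O)cc1)c1c(NO)cc(-c2ccccc2)oc1=O` gives > 20000 nM, again a limit. The steps a step that the two limits leave unreadable from compound 1 to compound 3 and a step that the two limits leave unreadable from compound 2 to compound 3 therefore cannot be sized, and all three values sit at the limit of > 20000 nM in this assay, at which 3 of the 3 values shown sit. Compound 4 `Cc1cccc(NC(=O)c2c(NO)cc(-c3ccccc3)oc2=O)c1` differs from compound 3 by 3-methylphenyl in place of 4-methoxyphenyl on an amide-type nitrogen. No step beyond the scatter is expected, since the comparable changes a step that the two limits leave unreadable from compound 1 to compound 3 and a step that the two limits leave unreadable from compound 2 to compound 3 both remain at the limit of > 20000 nM in this assay, at which 3 of the 3 values shown sit, so the step that the limit leaves unreadable from compound 3 to compound 4 is estimated to be negligible. Compound 4 is accordingly expected to give 25000 nM in this assay, within 8000 nM to 80000 nM.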

Compound 4, half-maximal cytotoxic concentration: > 20000 nM
Compound 4: a limit, no number (the forecaster's own chance of this, stated with the estimate: 80%); the middle value lies beyond the limit too.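

Within the data shown here, compound 4 joins compound 1, compound 2 and compound 3 at a limit, so no step among them can be read: the limit of > 20000 nM in this assay, at which 4 of the 4 values shown sit. In this assay the compounds shown leave open the concentration at which any of them turns toxic.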